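A few compounds are considered here, and "the series" means these few. Any claim that something is new, unique, unknown or untested is made for them only; others in the source may bear on it.

Compound 1 `O=S(=O)(NCCCCCCCCn1cc(-c2cccnc2)nn1)c1ccccc1Br`: 171 nM
Compound 2 `O=S(=O)(NCCCCCCn1cc(-c2cccnc2)nn1)c1ccccc1Br`: 175 nM

Both compounds were tested in a functional assay on SH-SY5Y cells (Homo sapiens) for cytotoxicity, read by MTT assay, with a stated time of 56 h; a higher number here means that more compound is needed for the effect, a lower number that less compound is needed. Compound 1 has the lowest number of the two, but its gap to compound 2 lies within the usual scatter of repeated measurements, so the two cannot be told apart.

Compound 3 `O=S(=O)(NCCCCCCCCn1cc(-c2cccnc2)nn1)c1ccccc1-c1ccccc1` has not been measured yet. It is compound 1 with phenyl in place of bromo, on an aromatic carbon of a six-membered aromatic ring of carbon only, ortho to a large group: phenyl in place of bromo on an aromatic carbon. The rest of the structure stays the same.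

Going by the values given here, no measured pair shows what this kind of swap does in this assay, so any forecast carries real uncertainty. The starting point is compound 1 at 171 nM. The expectation is no step beyond the scatter, with a slight lean towards a higher number, though a larger step either way cannot be ruled out. The estimate amounts to an expected 1.5-fold higher number from compound 1 to compound 3 (0.16 log units; within the scatter). For compound 3 the expected value is 250 nM, with an estimated range of 60 nM to 1000 nM.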

Compound 3, half-maximal effective concentration: 12.6 nM
Estimate against measurement, compound 3: 20-fold (1.30 log units) above; measured number below the stated range.
By their numbers in this assay, from the lowest: compound 3; then compounds 1 and 2 (each within the scatter of the next).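

In this assay, putting phenyl in place of bromo gives a 14-fold lower number from compound 1 to compound 3 (1.13 log units; beyond the scatter), so less compound is needed for the effect once a carbon ring stands where the bromine stood. Going by these compounds alone, this is the first sign that the group at this ring position, ortho to a large group, can strongly move the number; compounds 1 and 2 both carry bromo, differ only in chain length and lie within the scatter of each other, so they could say nothing about this spot. No measurement in hand explains why this swap lowers the number.

The compounds shown leave open whether any group larger than bromo would do the same or whether an aromatic ring is needed, a question that a cyclohexyl or a pyridyl group at this position, or a phenyl ring carrying a methoxy or an amine, would help to settle. They also leave open whether the shorter chain of compound 2 would respond to phenyl in the same way as the longer chain of compound 1.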